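A Fluorine Added to the Shared Core

The compounds below may be only part of what the source reports. "The series", "measured", "known", "first", "only" and "open" are said of these compounds alone.

Three compounds have been measured in an ADME assay on cells (Hepatocyte, Homo sapiens) for metabolic stability; on this read-out lower numbers stand for slow clearance and higher numbers for fast clearance:

Compound 1 `C[C@H](Oc1cc2cc(C(N)=O)ccc2nc1N)c1cc(F)ccc1-n1cccn1` gives 13 uL/min.
Compound 2 `C[C@H](Oc1cc2cc(C(N)=O)ccc2nc1N)c1ncc(F)cc1-n1cccn1` gives < 2 uL/min, which is a limit of the assay and not a number.
Compound 3 `C[C@H](Oc1cc2cc(C(N)=O)ccc2nc1N)c1cc2[nH]ncc2cc1-n1cccn1` gives < 3 uL/min, also a limit of the assay rather than a number.

Compound 2 therefore stands at the lower edge of what this assay can report. For the measured compounds named here, its result is one of two limits among the three values shown, the other belonging to compound 3, while compound 1 is the only compound of the three with a measured number.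

Compound 4 `C[C@H](Oc1cc2cc(C(N)=O)cc(F)c2nc1N)c1ncc(F)cc1-n1cccn1` differs from compound 2 in one place: fluoro in place of hydrogen on an aromatic carbon. The change sits on the shared core, ortho to a fused ring, meta to a carbamoyl group and meta to a fused ring. Going by the values given here, no step between two measured compounds has been recorded, so nothing among the measured values speaks for a shift in this assay in either direction, and the step is expected to stay within the usual scatter.

Compound 4 is expected to give about 2 uL/min, in the range 1 uL/min to 5 uL/min, an estimated step of a number no lower from compound 2 to compound 4 (the limit leaves the size open), most likely again reported only as a limit.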

Compound 4, intrinsic clearance in a liver preparation (reported as CLH), per the amount of preparation that the assay uses: 4 uL/min
Estimate against measurement, compound 4: 2.0-fold (0.30 log units) below; the measured number falls inside the stated range.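

In this assay, for the compounds shown here, fluoro in place of hydrogen on an aromatic carbon of the shared core, ortho to a fused ring, yields the first step that can be read, an at least 2.0-fold higher number from compound 2 to compound 4 (0.30 log units; that floor lies within the scatter), and this is all the data show about the change. Compound 4 gives 4 uL/min, a measured number, so the core can carry this fluoro and still return a value in this assay. The floor of the step does not separate the change from the usual scatter. Going by these compounds, the true size of the step remains unknown because compound 2 is reported only as a limit of the assay and not as a number: the limit of < 2 uL/min in this assay, at which 1 of the 4 values shown sits.

The compounds shown leave open whether the same fluoro would produce a readable shift on the core of compound 1, which gives 13 uL/min and so offers a measured number as a starting point. They also leave open how chloro, methoxy or nitrile on the same aromatic carbon would read in this assay, since fluoro is the only group shown there in place of hydrogen.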